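Adding a Chloro to the Anilino Ring of Compound 3

The source may report more compounds than this note shows. Statements on the series, on what has been measured and on what is new or still open speak of the compounds shown alone.

Three related compounds have been tested in a functional assay on HEK293 cells for agonist activity at probable G-protein coupled receptor 27 (Homo sapiens), read by a luciferase reporter and beta-arrestin recruitment, with a stated time of 10 min; on this read-out lower numbers stand for an effect already at smaller amounts and higher numbers for an effect only at larger amounts of compound. Compound 1 `COc1ccc(NS(=O)(=O)c2ccc(NC(=O)c3ccc(Cl)cc3Cl)cc2)cc1` gives > 100000 nM, which is a limit of the assay and not a number. Compound 2 `O=C(Nc1ccc(S(=O)(=O)Nc2ccc(Cl)cc2)cc1)c1ccc(Cl)cc1Cl` likewise gives only a limit, > 100000 nM. Within the data shown here, compound 3 `O=C(Nc1ccc(S(=O)(=O)Nc2ccccc2)cc1)c1ccc(Cl)cc1Cl` gives 457 nM, the only real number among the three. The step that the two limits leave unreadable from compound 1 to compound 2 cannot be read because of the limit of > 100000 nM in this assay, at which 2 of the 3 values shown sit. The steps of an at least 210-fold lower number from compound 1 to compound 3 (2.34 log units; beyond the scatter) and an at least 210-fold lower number from compound 2 to compound 3 (2.34 log units; beyond the scatter) are both large: taking away the methoxy or the chloro lowers the number at least that far.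

Compound 4 `O=C(Nc1ccc(S(=O)(=O)Nc2ccccc2Cl)cc1)c1ccc(Cl)cc1Cl` differs from compound 3 by chloro in place of hydrogen on an aromatic carbon. Among the measured compounds shown here, the measured steps show that a chloro or a methoxy on the anilino ring can remove all measurable activity, yet the chloro in compound 4 stands at a different place, ortho to a large group, and no measured pair tests that place. The expected step of a 4.4-fold higher number from compound 3 to compound 4 (0.64 log units; beyond the scatter) is therefore a moderate rise in the number, with wide uncertainty. Compound 4 is estimated at 2000 nM, between 300 nM and 60000 nM.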

Compound 4, half-maximal effective concentration: 1260 nM
Beside the measured number, compound 4's estimate is 1.6-fold (0.20 log units) above it, within the range that was stated.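

A chloro on the anilino ring does not by itself remove activity: ortho to a large group it keeps a measurable number, with a 2.8-fold higher number from compound 3 to compound 4 (0.44 log units; beyond the scatter). Among these compounds, then, the place of the substituent counts for much more than its mere presence, as 2-chlorophenyl in place of 4-chlorophenyl gives an at least 79-fold lower number from compound 2 to compound 4 (1.89 log units; beyond the scatter), and 2-chlorophenyl in place of 4-methoxyphenyl gives an at least 79-fold lower number from compound 1 to compound 4 (1.89 log units; beyond the scatter). Those two sizes are only minimums, since compound 1 and compound 2 each give a limit of the assay and not a number: the limit of > 100000 nM in this assay, at which 2 of the 4 values shown sit.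

The compounds shown leave open whether a fluoro, a methyl or an amine at the same place would give a number close to that of compound 3 or lose activity. They also leave open how a chloro on the remaining carbons of this ring would read.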